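Bromo to methoxy in a cytotoxicity test

A few compounds are considered here, and "the series" means these few. Any claim that something is new, unique, unknown or untested is made for them only; others in the source may bear on it.

Compound 1 `Cn1cc(C2CC(c3ccccc3)=NN2C(=O)c2cccnc2)c2ccccc21` gives > 300000 nM (a limit)
Compound 2 `Cn1cc(C2CC(c3ccccc3)=NN2C(=O)c2cccnc2)c2cc(Br)ccc21` gives > 300000 nM (a limit)

In an ADME assay on HEK-293T cells (Homo sapiens) for cytotoxicity, read by MTT assay, with a stated time of 48 h (a higher number here means that more compound is tolerated, a lower number that less compound is tolerated), compound 2 gives > 300000 nM as a limit and not a number. Both measured compounds share the limit of > 300000 nM in this assay, at which 2 of the 2 values shown sit, and neither gives an exact value. Compound 3 `COc1ccc2c(c1)c(C1CC(c3ccccc3)=NN1C(=O)c1cccnc1)cn2C` has methoxy in place of bromo on an aromatic carbon. Among the compounds with values here, the one measured step (a step that the two limits leave unreadable from compound 1 to compound 2) is also a change on an aromatic carbon, but its size cannot be read. So a number no higher from compound 2 to compound 3 (the limit leaves the size open) is expected to stay within the scatter in this assay and another limit is likely. The estimate for compound 3 is 300000 nM with 150000 nM to 1000000 nM as its expected range.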

Compound 3, half-maximal cytotoxic concentration: > 300000 nM
Compound 3 was reported as a limit; the forecaster's own chance of this, stated with the estimate: 85%; the middle value sits exactly at the limit.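

No new step can be read among compound 1, compound 2 and compound 3, since each gives only a limit and not a number: the limit of > 300000 nM in this assay, at which 3 of the 3 values shown sit.

As far as these compounds go, whether hydrogen, bromo or methoxy on this aromatic carbon makes any difference in this assay stays open.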